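A few compounds are considered here, and "the series" means these few. Any claim that something is new, unique, unknown or untested is made for them only; others in the source may bear on it.

Working notes on the series. Three compounds sharing one core have been run through a functional assay on A549 cells (Homo sapiens) for cytotoxicity, read by MTT assay, with a stated time of 24 h (on this read-out lower numbers stand for stronger inhibition and higher numbers for weaker inhibition), so far. Compound 1 `O=C(O)c1ccc(CN2C(=O)S/C(=C\c3cccnc3)C2=O)cc1` gives 75000 nM in this assay. Compound 2 `O=C(O)c1ccc(CN2C(=O)S/C(=C\c3ccc(Br)cc3)C2=O)cc1` gives 42000 nM, and compound 3 `COc1cccc(/C=C2\SC(=O)N(Cc3ccc(C(=O)O)cc3)C2=O)c1` gives 55000 nM. Going by the values given here, compound 1 holds the highest of the three numbers, yet no step away from it clears the scatter: a 1.8-fold lower number from compound 1 to compound 2 (0.25 log units; within the scatter) and a 1.4-fold lower number from compound 1 to compound 3 (0.13 log units; within the scatter). Between the other two, a 1.3-fold higher number from compound 2 to compound 3 (0.12 log units; within the scatter), again inside the scatter.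

Compound 4 `Cc1ccc(/C=C2\SC(=O)N(Cc3ccc(C(=O)O)cc3)C2=O)cc1` is not yet measured. It differs from compound 1 in one place, (4-methylphenyl in place of pyridin-3-yl on a double-bonded chain carbon bound to a double-bonded ring carbon). Among the compounds with values here, the two earlier replacements of pyridin-3-yl at the same place are the steps that bear on it, and both stayed within the scatter, so in this assay no step beyond the scatter is expected for compound 4 either, if anything a somewhat lower number. Compound 4 is therefore expected to give 50000 nM, with a range from 25000 nM to 100000 nM. The expected step is a 1.5-fold lower number from compound 1 to compound 4 (0.18 log units; within the scatter), itself within the scatter.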

Compound 4, half-maximal inhibitory concentration: 78000 nM
Compound 4: middle estimate off by 1.6-fold (0.19 log units), on the low side, within the range that was stated.
By their numbers in this assay, from the lowest: compounds 2, 3, 1 and 4 (each within the scatter of the next).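

At the place on a double-bonded chain carbon bound to a double-bonded ring carbon, 4-methylphenyl joins the other aromatic groups in staying inside the scatter in this assay (a 1.0-fold higher number from compound 1 to compound 4 (0.02 log units; within the scatter); a 1.4-fold higher number from compound 3 to compound 4 (0.15 log units; within the scatter)). Keeping the aromatic ring and exchanging only its substituent, the methyl in place of bromo step (a 1.9-fold higher number from compound 2 to compound 4 (0.27 log units; within the scatter)) also stays inside the scatter, so these two substituents cannot be told apart here and the four compounds cannot be ordered. Nothing at hand offers an explanation for this lack of separation.

All groups shown at this place are six-membered aromatic rings, so what a saturated cyclohexyl group or a 4-aminophenyl group would give stays open. Also open, on these data alone, is whether any replacement at this place can produce a step beyond the scatter.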